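A few compounds are considered here, and "the series" means these few. Any claim that something is new, unique, unknown or untested is made for them only; others in the source may bear on it.

The compounds measured so far in a functional assay on CCRF-CEM cells for agonist activity at C-X-C chemokine receptor type 4 (Homo sapiens), read by calcium flux, with a stated time of 25 min; a higher number here means that more compound is needed for the effect, a lower number that less compound is needed:

Compound 1 `c1cnc2c(c1)CCC[C@@H]2N(CC1CC1)C[C@H]1Cc2c(cccc2N2CCNCC2)CN1` gives > 30000 nM, which is a limit of the assay.
Compound 2 `CN(C[C@H]1Cc2c(cccc2N2CCN(c3cccc(C(F)(F)F)c3)CC2)CN1)[C@H]1CCCc2cccnc21` gives > 30000 nM, which is a limit of the assay.
Compound 3 `CN(C[C@H]1Cc2c(cccc2N2CCN(c3ccccn3)CC2)CN1)[C@H]1CCCc2cccnc21` gives > 30000 nM, which is a limit of the assay.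

Compound 1 therefore stands at a limit and not at a number, and every value shown so far sits at the same limit (the limit of > 30000 nM in this assay, at which 3 of the 3 values shown sit). For the measured compounds named here, the single step between measured compounds that differ in one place, a step that the two limits leave unreadable from compound 2 to compound 3, runs from one limit to another, so its size cannot be read. Compound 4 `CCN(C[C@H]1Cc2c(cccc2N2CCNCC2)CN1)[C@H]1CCCc2cccnc21` differs from compound 1 by methyl in place of cyclopropyl on a saturated chain carbon bound to an amine nitrogen, a change that, cut one bond further out, reads cyclopropylmethyl to ethyl. Going by the values given here, no measured step bears on this change, and the one step available is unreadable. Because compound 1 sits at the limit of > 30000 nM in this assay, at which 3 of the 3 values shown sit, compound 4 is expected to stay near that limit rather than to move to a readable number. The expected step that the limit leaves unreadable from compound 1 to compound 4 is thus none beyond the scatter. Compound 4 is estimated at 40000 nM, in a range from 10000 nM to 150000 nM, most probably reported again only as a limit.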

Compound 4, half-maximal effective concentration: > 30000 nM
Compound 4: no number, only a limit (the forecaster's own chance of this, stated with the estimate: 80%); the middle value is on the limit's open side.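

Compound 4 gives > 30000 nM, which is a limit of the assay, and compound 1 also stands at a limit, so the step between compound 1 and compound 4 cannot be read. The compounds shown leave open how far any structural change moves the read-out, as all sit at one limit: the limit of > 30000 nM in this assay, at which 4 of the 4 values shown sit.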